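The source may hold more compounds than are shown below. What is called first, only, known or untested is meant among the compounds shown, and "the series" means these compounds.

Compound 1 `CC(C)=CC[C@@H](OC(=O)C(Cl)(Cl)Cl)C1=CC(=O)c2c(O)ccc(O)c2C1=O` gives 115000 nM in an assay on HeLa cells for inhibition of DNA topoisomerase 1 (Homo sapiens); on this read-out higher numbers stand for weaker inhibition and lower numbers for stronger inhibition.
Compound 2 `CC(C)=CC[C@@H](OC(=O)C(C)C)C1=CC(=O)c2c(O)ccc(O)c2C1=O` gives 84000 nM in this assay.
Compound 3 `CC/C=C/CC(=O)O[C@H](CC=C(C)C)C1=CC(=O)c2c(O)ccc(O)c2C1=O` gives 153000 nM in this assay.

Compound 3 has the highest of these three numbers, but neither gap reaches beyond the scatter: a 1.3-fold higher number from compound 1 to compound 3 (0.12 log units; within the scatter) and a 1.8-fold higher number from compound 2 to compound 3 (0.26 log units; within the scatter). Compound 4 `C=CCCCCC(=O)O[C@H](CC=C(C)C)C1=CC(=O)c2c(O)ccc(O)c2C1=O` differs from compound 3 only in the chain of the ester group: pent-4-en-1-yl in place of but-1-en-1-yl on a saturated chain carbon bound to a carbonyl carbon. Every measured step among compounds 1, 2 and 3 exchanges this same acyl chain, and each stayed within the scatter: a 1.4-fold lower number from compound 1 to compound 2 (0.14 log units; within the scatter), a 1.3-fold higher number from compound 1 to compound 3 (0.12 log units; within the scatter), a 1.8-fold higher number from compound 2 to compound 3 (0.26 log units; within the scatter). On that basis compound 4 is expected to show no step beyond the scatter in this assay, a 1.0-fold lower number from compound 3 to compound 4 (0.01 log units; within the scatter). Compound 4 is estimated at 150000 nM, with a range from 70000 nM to 320000 nM.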

Compound 4, half-maximal inhibitory concentration: 250000 nM
Compound 4: middle estimate off by 1.7-fold (0.22 log units), on the low side, within the range that was stated.
By their numbers in this assay, from the lowest: compounds 2, 1, 3 and 4 (each within the scatter of the next, the first and the last beyond it).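

In this assay, for the compounds shown here, the hex-5-en-1-yl chain on the carbonyl carbon gives the first steps at this position that pass the scatter, both modest and both toward weaker inhibition (a 3.0-fold higher number from compound 2 to compound 4 (0.47 log units; beyond the scatter); a 2.2-fold higher number from compound 1 to compound 4 (0.34 log units; beyond the scatter)). The step from the closest relative stays within the scatter (a 1.6-fold higher number from compound 3 to compound 4 (0.21 log units; within the scatter)), so the acyl chain can shift the number here, but only slightly. No measured evidence here accounts for this shift.

The compounds shown leave open whether a longer chain would weaken inhibition further. They also leave open how a saturated hexyl chain, or an acyl chain carrying an amine, would compare.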